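Quinoline benzamide series: aryl replacement on the carbonyl

This account rests on a few compounds, and the source may have more. Where it says the series, first, only, none or still open, it means among the compounds named here.

Measured so far:
compound 1, `CCN1CCN(c2cc(C)c3cc(NC(=O)c4ccccc4)ccc3n2)CC1`, gives 18400 nM
compound 2, `CCc1ccccc1C(=O)Nc1ccc2nc(N3CCN(CC)CC3)cc(C)c2c1`, gives 23900 nM

Both numbers come from a functional assay on SK-BR-3 cells (Homo sapiens) for antiproliferative activity, read by MTT assay, with a stated time of 72 h; a lower number here means a stronger inhibitor, a higher number a weaker inhibitor. Among the compounds with values here, compound 2 holds the higher of the two, but its only neighbour is compound 1, and the single measured step, a 1.3-fold higher number from compound 1 to compound 2 (0.11 log units; within the scatter), lies within the scatter, so the two compounds cannot be told apart on these data.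

Compound 3, `CCN1CCN(c2cc(C)c3cc(NC(=O)c4ccc(Cl)c(Cl)c4)ccc3n2)CC1`, is not yet measured. It differs from compound 2 only in the group on the carbonyl carbon: 3,4-dichlorophenyl in place of 2-ethylphenyl on a carbonyl carbon. Within the data shown here, the one step that bears on this, a 1.3-fold higher number from compound 1 to compound 2 (0.11 log units; within the scatter), shows that altering the aromatic ring on the carbonyl left the number essentially unchanged, though that step involved a different group. Among the measured compounds shown here, no measured pair shows what a dichloro replacement does. The expected step of a 1.6-fold lower number from compound 2 to compound 3 (0.20 log units; within the scatter) is therefore a small one, with only a slight lean toward a lower number. For compound 3 the estimate in this assay is 15000 nM, with a range from 5000 nM to 45000 nM.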

Compound 3, half-maximal inhibitory concentration: 2160 nM
Estimate against measurement, compound 3: 6.9-fold (0.84 log units) above, and the stated range ends above it.
By their numbers in this assay, from the lowest: compound 3; then compounds 1 and 2 (each within the scatter of the next).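

Working notes, carbonyl aryl group: in this assay, the group on the carbonyl carbon can shift the number substantially, a point that the earlier step (a 1.3-fold higher number from compound 1 to compound 2 (0.11 log units; within the scatter)) could not establish, as it lay within the scatter. Replacing 2-ethylphenyl with 3,4-dichlorophenyl gives a large step (an 11-fold lower number from compound 2 to compound 3 (1.04 log units; beyond the scatter)), and replacing phenyl with 3,4-dichlorophenyl gives a modest one in the same direction (an 8.5-fold lower number from compound 1 to compound 3 (0.93 log units; beyond the scatter)), so among the three compounds shown, compound 3 is the strongest inhibitor, with both steps beyond the scatter. Nothing available here accounts for the drop in the number.

The compounds shown leave open whether both chlorines are required, and whether a single chlorine, a bromine or a trifluoromethyl group on the same ring would give a comparable number. They also leave open whether the gain carries over to a different group on the piperazine nitrogen, such as methyl or acetyl, in place of the ethyl shared by all three compounds.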